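Compound 3 to compound 4: a benzyl exchange

This account rests on a few compounds, and the source may have more. Where it says the series, first, only, none or still open, it means among the compounds named here.

In a functional assay on K562 cells (Homo sapiens) for antiproliferative activity, with a stated time of 72 h (a lower number here means a stronger inhibitor, a higher number a weaker inhibitor), compound 1 `OC[C@H]1O[C@@H](n2cnc3c(NCc4ccccc4F)ncnc32)[C@H](O)[C@@H]1O` gives 33200 nM and compound 2 `COc1ccccc1CNc1ncnc2c1ncn2[C@@H]1O[C@H](CO)[C@@H](O)[C@H]1O` gives 89000 nM. Compound 3 `OC[C@H]1O[C@@H](n2cnc3c(NCc4cc(O)cc(O)c4)ncnc32)[C@H](O)[C@@H]1O` reaches only a limit of the assay, > 166000 nM, not a number. Compound 4 `Cc1ccc(O)c(CNc2ncnc3c2ncn3[C@@H]2O[C@H](CO)[C@@H](O)[C@H]2O)c1` differs from it by 2-hydroxy-5-methylphenyl in place of 3,5-dihydroxyphenyl on a saturated chain carbon bound to a nitrogen on an aromatic ring: 3,5-dihydroxybenzyl to 2-hydroxy-5-methylbenzyl. Two measured steps change the same place: an at least 5.0-fold higher number from compound 1 to compound 3 (0.69 log units; beyond the scatter) and an at least 1.8-fold higher number from compound 2 to compound 3 (0.27 log units; that floor lies within the scatter). Between the two numbered compounds, the step is a 2.7-fold higher number from compound 1 to compound 2 (0.43 log units; beyond the scatter). The entering group shares its 2-substituted pattern by name with compound 1 and compound 2, so a modest step to a lower number is expected in this assay. The expected step is an at least 2.0-fold lower number from compound 3 to compound 4 (0.31 log units; beyond the scatter). For compound 4 the estimated value is 80000 nM, with a range of 30000 nM to 170000 nM.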

Compound 4, half-maximal inhibitory concentration: 16500 nM
Compound 4: the middle estimate sits 4.8-fold (0.69 log units) above what was measured; the measured number lies below the stated range.
By their numbers in this assay, from the lowest: compounds 4 and 1 (each within the scatter of the next); then compound 2. At a limit, above all of these: compound 3.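

In this assay, a hydroxy-bearing benzyl at this place need not sit at the weak end of the series, with an at least 10-fold lower number from compound 3 to compound 4 (1.00 log units; beyond the scatter) and a 5.4-fold lower number from compound 2 to compound 4 (0.73 log units; beyond the scatter). Against the fluoro analogue the result is a 2.0-fold lower number from compound 1 to compound 4 (0.30 log units; within the scatter), so no order holds for that pair. The first of these steps is only a floor, since compound 3 stands at a limit of the assay: the limit of > 166000 nM in this assay, at which 1 of the 4 values shown sits.

The contributions of the hydroxy and methyl groups within 2-hydroxy-5-methylbenzyl remain unseparated. Going by these compounds, how an amine or a carboxylic acid on the benzyl ring would read here also stays open.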